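Methyl for Methoxy: Expected Half-Life of Compound 4

This account rests on a few compounds, and the source may have more. Where it says the series, first, only, none or still open, it means among the compounds named here.

Measured so far:
compound 1 `COc1cnc(C[S+]([O-])c2nc3cc(OC(F)F)ccc3[nH]2)c(C)c1OC`, 3.7 h
compound 2 `COc1c(C)cnc(C[S+]([O-])c2nc3cc(OC(F)F)ccc3[nH]2)c1C`, 1.9 h
compound 3 `COc1cc2[nH]c([S+]([O-])Cc3nccc(OC)c3OC)nc2cc1OC(F)F`, 2.1 h

These values come from an ADME assay, at pH 5; a lower number here means that the compound disappears faster, a higher number that the compound lasts longer. Compound 1 and compound 2 differ in one place: methyl in place of methoxy on an aromatic carbon. That change gave a 1.9-fold lower number from compound 1 to compound 2 (0.29 log units; within the scatter). Compound 3 resembles compound 1, but the difference between the two cores is not broken down here. Compound 4 `COc1cc2[nH]c([S+]([O-])Cc3nccc(OC)c3C)nc2cc1OC(F)F` is not yet measured; it differs from compound 3 by methyl in place of methoxy on an aromatic carbon. Among the compounds with values here, this is the same kind of change as the one from compound 1 to compound 2, though the surroundings differ: in compound 4 the methyl sits ortho to a large group, whereas in compound 2 it sits meta to a methyl group and para to a large group. Since the earlier step, a 1.9-fold lower number from compound 1 to compound 2 (0.29 log units; within the scatter), stayed within the scatter, compound 4 is expected to show a 1.8-fold lower number from compound 3 to compound 4 (0.24 log units; within the scatter). Compound 4 is estimated at 1.2 h, likely between 0.6 h and 2.4 h.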

Compound 4, half-life: 0.2 h
Compound 4: the middle estimate sits 6.0-fold (0.78 log units) above what was measured; measured number below the stated range.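

In this assay, methyl in place of methoxy gave an 11-fold lower number from compound 3 to compound 4 (1.02 log units; beyond the scatter), so the size of the step seen on one core did not carry over to the other: the same change on two cores in this assay, a 1.9-fold lower number (0.29 log units; within the scatter) from compound 1 to compound 2 and an 11-fold lower number (1.02 log units; beyond the scatter) from compound 3 to compound 4, 5.4-fold (0.73 log units) apart, beyond the scatter of two such steps

Within the data shown here, only the step on the core of compound 3 lies beyond the scatter, so a step measured on one core is a poor guide to the same change on another. These two pairs do not show why the cores differ, and they say nothing about how the change would behave on any further core.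

From the compounds shown here alone, it remains open whether an ethyl group, a chlorine atom or an amine at this place would last as briefly as the methyl of compound 4 or as long as the methoxy of compound 3.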